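The compounds below may be only part of what the source reports. "The series", "measured", "known", "first", "only" and "open" are said of these compounds alone.

Two members of this series of diterpenoid-type compounds have been measured so far. Compound 1 `C=C(CC[C@H]1C(=C)CC[C@H]2[C@@](C)(CO)CCC[C@]12C)C(=O)CO` in a functional assay on MDA-MB-231 cells (Homo sapiens) for inhibition, read by MTT assay (on this read-out higher numbers stand for weaker inhibition and lower numbers for stronger inhibition), gives 19.9 ug/mL. Compound 2 `C=C(C=O)CC[C@H]1C(=C)CC[C@@H]2[C@]1(C)CCC[C@]2(C)C(=O)O` in this assay gives 14.1 ug/mL; the two numbers lie within the scatter of each other, so compound 2 cannot be set apart from compound 1 on these data. No change between measured compounds has been characterised, so the effect of altering the side chain on the shared core is not known from this set.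

Compound 3 `C=C1CC[C@@H]2[C@](C)(CCC[C@]2(C)C(=O)O)[C@H]1CC/C(C)=C/CO` differs from compound 2 as follows: 3-hydroxy-1-methylprop-1-en-1-yl in place of 1-formylethenyl on a saturated chain carbon, two bonds along the chain from a saturated ring carbon. Among the compounds with values here, with no comparable step available, the expectation is that the change from compound 2 to compound 3 moves this assay by a 1.4-fold higher number from compound 2 to compound 3 (0.15 log units; within the scatter), which would be no more than the scatter. Compound 3 is therefore estimated at 20 ug/mL, with a range from 9 ug/mL to 45 ug/mL.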

Compound 3, half-maximal inhibitory concentration: "not active" (no number reported)
Compound 3: no number reported, so the estimate cannot be set against anything.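

Within the data shown here, compound 3 is reported only as "not active" in this assay, with no number, so no step from compound 2 to compound 3 can be read. Nothing available bears on this result. Going by these compounds, how far 3-hydroxy-1-methylprop-1-en-1-yl in place of 1-formylethenyl shifts the read-out on the shared core stays open.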